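Acetylation of a ring hydroxyl in a terpenoid ester series

This account rests on a few compounds, and the source may have more. Where it says the series, first, only, none or still open, it means among the compounds named here.

Of the compounds shown here, three have been measured in a functional assay on Jurkat cells (Homo sapiens) for cytotoxicity, read by MTT assay, with a stated time of 72 h; a lower number here means a stronger inhibitor, a higher number a weaker inhibitor. Compound 1 `COc1ccc(C(=O)O[C@H]2CC(C)=C[C@@H](OC(C)=O)[C@@]3(C)[C@@H](OC(C)=O)C[C@@](O)(C(C)C)[C@H]23)cc1` gives 62200 nM. Compound 2 `COc1ccc(C(=O)O[C@H]2CC(C)=C[C@H](OC(C)=O)[C@]3(C)[C@@H]2[C@](O)(C(C)C)C[C@@H]3O)cc1` gives 9100 nM, the lowest number of the three, and both other compounds stand beyond the scatter of it. Compound 3 `COc1ccc(C(=O)O[C@H]2CC(C)=C[C@@H](O)[C@@]3(C)[C@@H](OC(C)=O)C[C@@](O)(C(C)C)[C@H]23)cc1` gives 33600 nM.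

Compound 3 and compound 1 share a core and differ in one place: acetyl in place of hydrogen on an oxygen on a saturated carbon. This change produced a 1.9-fold higher number from compound 3 to compound 1 (0.27 log units; within the scatter), so the acetylation left the read-out essentially unchanged on that core.

Compound 2 and compound 3 have the same atoms joined differently; the difference between the two cores is not broken down here.

Compound 4 `COc1ccc(C(=O)O[C@H]2CC(C)=C[C@H](OC(C)=O)[C@@]3(C)[C@@H](OC(C)=O)C[C@@](O)(C(C)C)[C@H]23)cc1` is not yet measured. It differs from compound 2 by acetyl in place of hydrogen on an oxygen on a saturated carbon. The place of the change reads word for word as for the pair of compound 3 and compound 1, so this is the same change carried onto the core of compound 2. The change occurs twice in the series, once measured and once pending.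

The expected step is a 1.6-fold higher number from compound 2 to compound 4 (0.22 log units; within the scatter), a small one lying beside the measured step, because the same change gave a 1.9-fold higher number from compound 3 to compound 1 (0.27 log units; within the scatter). This rests on a single measured pair on a different core, so the range is kept wide. Compound 4 is expected at 15000 nM, with an estimated range from 6000 nM to 40000 nM.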

Compound 4, half-maximal inhibitory concentration: 3300 nM
Compound 4: the middle estimate sits 4.5-fold (0.66 log units) above what was measured, outside the stated range (below it).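

In this assay the acetylation does not carry over unchanged from one core to the other: the hydroxy to acetoxy change gives a 2.8-fold lower number from compound 2 to compound 4 (0.44 log units; beyond the scatter), and this step stands apart from the earlier one: the same change on two cores in this assay, a 1.9-fold higher number (0.27 log units; within the scatter) from compound 3 to compound 1 and a 2.8-fold lower number (0.44 log units; beyond the scatter) from compound 2 to compound 4, 5.1-fold (0.71 log units) apart, beyond the scatter of two such steps. The two products of that change are themselves separated by a single stereocentre as drawn, and this one difference comes with a 19-fold lower number from compound 1 to compound 4 (1.28 log units; beyond the scatter), a large step: the fact that compounds 1 and 4 differ only in the configuration as drawn. Within these two pairs, the outcome of the acetylation therefore depends on the core, but the pairs do not show why it does, and they give no rule for predicting the step on any further core.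

Whether the step on the core of compound 2 belongs to acetyl alone stays open, since the compounds shown carry no longer acyl chain such as butanoyl and no methyl ether on that oxygen. On these data alone, it also remains open whether an amine at the same place would follow the core of compound 2 or the core of compound 3, and whether the gap between compound 1 and compound 4 would persist with a group other than acetyl on that oxygen.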